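This account rests on a few compounds, and the source may have more. Where it says the series, first, only, none or still open, it means among the compounds named here.

Measured compounds:
- compound 1 `OC[C@H]1O[C@@H](n2cnc3c(NCc4ccccc4F)ncnc32)[C@H](O)[C@@H]1O`: > 166000 nM
- compound 2 `OC[C@H]1O[C@@H](n2cnc3c(NCc4ccc(F)cc4)ncnc32)[C@H](O)[C@@H]1O`: "not determined" (no result reported)
- compound 3 `COc1cccc(CNc2ncnc3c2ncn3[C@@H]2O[C@H](CO)[C@@H](O)[C@H]2O)c1OC`: "not determined" (no result reported)

Working notes on the series. In a functional assay on B16 cells (Mus musculus) for antiproliferative activity, with a stated time of 72 h (a lower number here means a stronger inhibitor, a higher number a weaker inhibitor), compound 1 gives > 166000 nM, which is a limit of the assay and not a number. For compound 2 no result in this assay is reported. Compound 3 likewise carries no number in this assay, so its standing can only be set against the other entries: one value is a limit of > 166000 nM in this assay, at which 1 of the 3 values shown sits, and one entry has no result at all. Nothing in the measured set fixes a scale for compound 3.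

The next compound, compound 4 `COc1cccc(CNc2ncnc3c2ncn3[C@@H]2O[C@H](CO)[C@@H](O)[C@H]2O)c1O`, differs from compound 3 by hydrogen in place of methyl on an oxygen on an aromatic ring. No step between measured compounds is shown, so no size can be read from the series for a change of this kind. The only anchor in this assay is the limit of compound 1, and from that anchor a weak result is the default. No step beyond the scatter is expected in this assay from compound 3 to compound 4, and a limit rather than a number is a real possibility.

Compound 4 is expected in this assay at about 120000 nM, with a range from 30000 nM to 300000 nM.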

Compound 4, half-maximal inhibitory concentration: > 166000 nM
Compound 4 was reported as a limit; the forecaster's own chance of this, stated with the estimate: 60%; middle value at least 1.3-fold (0.14 log units) from the limit.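

In this assay compound 4 gives > 166000 nM as a limit of the assay and not a number. Compound 1 also stands at a limit, so no step can be read from compound 1 to compound 4: the limit of > 166000 nM in this assay, at which 2 of the 4 values shown sit. The compounds shown leave open whether any change on the shared core gives a readable number in this assay at all.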